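Ethoxy in place of chloro in a growth inhibitor

This account rests on a few compounds, and the source may have more. Where it says the series, first, only, none or still open, it means among the compounds named here.

Compound 1 `Cc1cc(-c2nc3ccccc3s2)ccc1N` - > 100000 nM (a limit)
Compound 2 `COc1ccc(-c2nc3cc(F)ccc3s2)cc1Cl` - 2500 nM

Of the compounds shown here, two have so far been tested in a functional assay on HCC 2998 cells (Homo sapiens) for antiproliferative activity; a lower number here means a stronger inhibitor of growth, a higher number a weaker inhibitor of growth. Compound 1 gives > 100000 nM, which is a limit of the assay and not a number. Among the measured compounds shown here, compound 2 gives 2500 nM, the only true number available, so it has no measured neighbour against which to be ranked more finely.

The next compound, compound 3 `CCOc1cc(-c2nc3cc(F)ccc3s2)ccc1OC`, carries ethoxy in place of chloro on an aromatic carbon, ortho to a methoxy group (ethoxy in place of chloro on an aromatic carbon). For the measured compounds named here, no measured pair shows this change, so any forecast is uncertain. A move towards stronger growth inhibition, beyond the usual scatter, is expected, though with little confidence in its size. The expected change is a 6.3-fold lower number from compound 2 to compound 3 (0.80 log units; beyond the scatter). For compound 3 the estimated value is 400 nM, with an expected range from 10 nM to 6000 nM.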

Compound 3, concentration for 50% growth inhibition: 3320 nM
Compound 3: middle estimate off by 8.3-fold (0.92 log units), on the low side; low and high end bracket the measured number.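

Putting ethoxy in place of chloro on this aromatic carbon, ortho to a methoxy group, gives in this assay a 1.3-fold higher number from compound 2 to compound 3 (0.12 log units; within the scatter). For this pair, then, the position takes ethoxy, with its 3 heavy atoms and 1 hydrogen-bond acceptor, and chloro, with its 1 heavy atom, with no difference that can be told apart from the scatter of the read-out. Nothing in the data shown offers a reason for this outcome.

Going by these compounds, whether a longer chain such as butoxy, an amine or a carboxylic acid on this same carbon would also leave the number within the scatter remains open. So does whether the result would hold if the neighbouring methoxy group gave way to a hydroxyl group.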